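The compounds below may be only part of what the source reports. "The series", "measured", "known", "first", "only" and "open" are said of these compounds alone.

Measured compounds:
compound 1, `COc1cc(-c2cc(/C=C/C(=O)c3ccc(N)cc3)[nH]n2)cc(OC)c1OC`, 4330 nM
compound 2, `COc1ccc(-c2cc(/C=C/C(=O)c3ccc(OC)c(OC)c3)[nH]n2)cc1`, 3550 nM
compound 3, `COc1ccc(-c2cc(/C=C/C(=O)c3ccc(N)cc3)[nH]n2)cc1`, 4950 nM

In a functional assay on A498 cells (Homo sapiens) for inhibition, read by sulforhodamine B assay, with a stated time of 48 h (a lower number here means a stronger inhibitor of growth, a higher number a weaker inhibitor of growth), compound 1 gives 4330 nM, the second highest of the three numbers. Its nearest neighbour is compound 3 at 4950 nM, and its furthest is compound 2 at 3550 nM; both gaps lie within the usual scatter, so the three measured compounds cannot be told apart by potency. Compound 4, `COc1ccc(C(=O)/C=C/c2cc(-c3cc(OC)c(OC)c(OC)c3)n[nH]2)cc1OC`, has not been measured. It differs from compound 1 in one place: 3,4-dimethoxyphenyl in place of 4-aminophenyl on a carbonyl carbon. For the measured compounds named here, with no step between measured compounds available, compound 2 is the only guide, and it carries the entering group. Compound 4 is therefore expected to land near compound 2, with an estimated step of a 1.2-fold lower number from compound 1 to compound 4 (0.09 log units; within the scatter) that stays within the scatter. The estimate for compound 4 is 3500 nM, within 1500 nM to 8000 nM.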

Compound 4, concentration for total growth inhibition: 2980 nM
For compound 4 the middle estimate is 1.2-fold (0.07 log units) above the measured one; low and high end bracket the measured number.
By their numbers in this assay, from the lowest: compounds 4, 2, 1 and 3 (each within the scatter of the next).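

In this assay, for the compounds shown here, the step at this carbonyl carbon, a 1.5-fold lower number from compound 1 to compound 4 (0.16 log units; within the scatter), is the first one measured, and it stays within the scatter. The 3,4-dimethoxyphenyl group has no hydrogen-bond donor, unlike 4-aminophenyl, yet the exchange gives no measurable change, so the donor of that group is not needed to hold this level of growth inhibition. Nothing available gives a reason for this result.

Going by these compounds, what remains open is whether any group at this carbon moves the number beyond the scatter. A phenyl ring carrying a carboxylic acid, or a simple methyl in place of the ring, could test this.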